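Adding a Chloro Group to the Sulfonyl Ring of Compound 1

This account rests on a few compounds, and the source may have more. Where it says the series, first, only, none or still open, it means among the compounds named here.

Compound 1 `CC(=O)/C(=C\c1c(-c2ccccc2)[nH]c2ccccc12)S(=O)(=O)c1ccccc1`: 400 nM
Compound 2 `COC(=O)/C(=C\c1c(-c2ccccc2)[nH]c2ccccc12)S(=O)(=O)c1ccccc1`: 1000 nM
Compound 3 `O=C(/C(=C\c1c(-c2ccccc2)[nH]c2ccccc12)S(=O)(=O)c1ccccc1)c1ccccc1`: 3000 nM

These three compounds were measured in a functional assay on MT4 cells (Homo sapiens) for antiproliferative activity, read by MTT assay, with a stated time of 96 h; a lower number here means that less compound is needed, a higher number that more compound is needed for the effect. Compound 1 gives the lowest number of the three: a 2.5-fold higher number from compound 1 to compound 2 (0.40 log units; beyond the scatter) and a 7.5-fold higher number from compound 1 to compound 3 (0.88 log units; beyond the scatter), with a 3.0-fold higher number from compound 2 to compound 3 (0.48 log units; beyond the scatter) between the other two. All three measured steps change the group attached to the carbonyl carbon. Compound 4 `CC(=O)/C(=C\c1c(-c2ccccc2)[nH]c2ccccc12)S(=O)(=O)c1ccc(Cl)cc1` differs from compound 1 in a different place: chloro in place of hydrogen on an aromatic carbon. Within the data shown here, no measured step touches this ring, so the measured steps give no guide to the size or direction of this change. For compound 4 the expected step in this assay is no change at the digits printed from compound 1 to compound 4 (within the scatter), nothing beyond the scatter. Compound 4 is therefore estimated at 400 nM, with a range from 130 nM to 1200 nM.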

Compound 4, half-maximal effective concentration: > 100000 nM
Compound 4: only a limit was reported; the forecaster's own chance of this, stated with the estimate: 5%; at least 250-fold (2.39 log units) between middle value and limit.
By their numbers in this assay, from the lowest: compound 1; then compound 2; then compound 3. At a limit, above all of these: compound 4.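

Among these compounds, the phenylsulfonyl ring, untouched by the earlier steps, proves far more sensitive than the group on the carbonyl carbon: adding one chloro gives an at least 250-fold higher number from compound 1 to compound 4 (2.39 log units; beyond the scatter). In this assay compound 4 gives > 100000 nM, which is a limit and not a number. A single heavy atom on an aromatic carbon, para to a large group, is thus enough to carry the number past the limit.

Chloro is the only group shown at this place, so it remains open whether fluoro, methyl or an amine there would behave the same way.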